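One added methyl on a small carbamate chain

This account rests on a few compounds, and the source may have more. Where it says the series, first, only, none or still open, it means among the compounds named here.

Compound 1 (`CCC(COC(N)=O)C(C)C`) gives 81 mg/kg
Compound 2 (`CCC(C)C(CC)COC(N)=O`) gives 96 mg/kg
Compound 3 (`CCCC(COC(N)=O)C(C)C`) is not yet measured

In a functional assay on the whole organism (strain Sprague-Dawley albino) with Rattus norvegicus as the target, with a stated time of 0.5 h (on this read-out lower numbers stand for an effect already at smaller amounts and higher numbers for an effect only at larger amounts of compound), both numbers were obtained. Compound 1 has a single measured neighbour, and the two numbers cannot be told apart. Compound 3 differs from compound 1 by one change (methyl in place of hydrogen on a saturated chain carbon, four bonds along the chain from an oxygen next to a carbonyl group). Read one bond further out, an ethyl becomes a propyl. Compound 2 carries a change described in the same words, and that measured step (a 1.2-fold higher number from compound 1 to compound 2 (0.07 log units; within the scatter)) is the only one that bears on this comparison. One step is thin evidence, but it gives no reason to expect a shift beyond the scatter in this assay in either direction. The expected step is therefore small (a 1.0-fold higher number from compound 1 to compound 3 (0.02 log units; within the scatter)). The expected value for compound 3 is 85 mg/kg (estimated range from 50 mg/kg to 145 mg/kg).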

Compound 3, dose for half-maximal effect: 107 mg/kg
For compound 3 the middle estimate is 1.3-fold (0.10 log units) below the measured one; measured number inside the range.
By their numbers in this assay, from the lowest: compounds 1, 2 and 3 (each within the scatter of the next).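

In this assay, lengthening the ethyl of compound 1 to a propyl gives a 1.3-fold higher number from compound 1 to compound 3 (0.12 log units; within the scatter). Together with the earlier step, this makes two changes described in the same words, and neither moves the dose beyond the usual scatter, so at this place on the small carbamate chain one added methyl has not yet produced a readable shift. The data shown offer no measured explanation for this flat result.

Still open, on these data alone, is whether a larger change at this place, such as a butyl or longer chain, a hydroxyl group or an amine, would shift the dose beyond the scatter. For the compounds shown here, with only three compounds in one whole-animal test, the limits of this flat stretch remain unknown.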